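A few compounds are considered here, and "the series" means these few. Any claim that something is new, unique, unknown or untested is made for them only; others in the source may bear on it.

In a functional assay on HEK293 cells for agonist activity at probable G-protein coupled receptor 27 (Homo sapiens), read by a luciferase reporter and beta-arrestin recruitment, with a stated time of 10 min (a higher number here means that more compound is needed for the effect, a lower number that less compound is needed), compound 3 `O=C(Nc1ccc(S(=O)(=O)Nc2ccccc2)cc1)c1ccc(Cl)cc1Br` gives 1020 nM, the only numerical result among the three measured compounds. Compound 1 `O=C(Nc1cccc(S(=O)(=O)Nc2ccccc2)c1)c1ccc(Cl)cc1Cl` reaches only the limit of this assay, recorded as > 100000 nM. Compound 2 `O=C(Nc1ccc(S(=O)(=O)NCc2ccccc2)cc1)c1ccc(Cl)cc1Cl` likewise stops at the limit of this assay, recorded as > 100000 nM. Going by the values given here, two of the three results therefore rest at the limit of > 100000 nM in this assay, at which 2 of the 3 values shown sit, leaving compound 3 as the sole anchor for any comparison. Compound 4 `O=C(Nc1ccc(S(=O)(=O)Nc2ccccc2)cc1)c1ccc(Cl)nc1F` has not yet been measured; it differs from compound 3 in one place, where (6-chloro-2-fluoropyridin-3-yl in place of 2-bromo-4-chlorophenyl on a carbonyl carbon). Among the compounds with values here, no measured pair with a single change exists to calibrate this step, so its size in this assay is uncertain; a loss beyond the scatter is nonetheless expected, a 3.4-fold higher number from compound 3 to compound 4 (0.54 log units; beyond the scatter). For compound 4 the expected value in this assay is estimated at 3500 nM, within a range from 600 nM to 40000 nM.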

Compound 4, half-maximal effective concentration: 2290 nM
Compound 4: middle estimate off by 1.5-fold (0.18 log units), on the high side; the measured number falls inside the stated range.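

In this assay, the change on the carbonyl carbon gives a 2.2-fold higher number from compound 3 to compound 4 (0.35 log units; beyond the scatter) and leaves compound 4 with a numerical result. This position therefore accepts 6-chloro-2-fluoropyridin-3-yl, a ring with a hetero atom and no bromine, at only a modest cost. Nothing measured here accounts for the size of this step. Which of the exchanged atoms carries the step remains open, as the ring nitrogen, fluorine and bromine change together. Also open, from the compounds shown here alone, is whether a saturated ring such as cyclohexyl, or an amine on the pyridine ring, would keep a numerical result.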